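Adding a methoxy group to compound 2

The compounds below may be only part of what the source reports. "The series", "measured", "known", "first", "only" and "open" are said of these compounds alone.

Two related compounds have been measured so far, and neither gives an exact number. In an ADME assay on HepG2 cells (Homo sapiens) for cytotoxicity, with a stated time of 72 h (on this read-out lower numbers stand for an effect already at smaller amounts and higher numbers for an effect only at larger amounts of compound), compound 1 (`COc1ccc(-c2nc3ccccc3o2)cc1NC(=O)c1cc([N+](=O)[O-])ccc1Cl`) gives > 25000 nM as a limit of the assay. In this assay compound 2 (`O=C(Nc1cccc(-c2nc3ccccc3s2)c1)c1cc([N+](=O)[O-])ccc1Cl`) gives > 27000 nM as a limit of the assay. Among the measured compounds shown here, compound 2 therefore stands at a limit, as does the only other value available.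

Compound 3 (`COc1ccc(-c2nc3ccccc3s2)cc1NC(=O)c1cc([N+](=O)[O-])ccc1Cl`) is compound 2 with methoxy in place of hydrogen on an aromatic carbon. The methoxy sits ortho to a large group and para to a 1,3-benzothiazol-2-yl group. For the measured compounds named here, no measured step between single-place analogues is available as a guide, so no shift beyond the usual scatter is expected. The expected step that the limit leaves unreadable from compound 2 to compound 3 is estimated to stay within that scatter. In this assay compound 3 is estimated at 30000 nM (range 12000 nM to 60000 nM).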

Compound 3, half-maximal effective concentration: > 25000 nM
Compound 3: only a limit was reported (the forecaster's own chance of this, stated with the estimate: 80%); the middle value does not contradict the limit.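

The steps from compound 2 to compound 3 and from compound 1 to compound 3 cannot be read: all three results in this assay are limits of the assay. The compounds shown leave open whether methoxy or 1,3-benzothiazol-2-yl in place of 1,3-benzoxazol-2-yl changes cytotoxicity at all.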